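A Methoxy Addition Repeated on a Smaller Side Chain

The compounds below may be only part of what the source reports. "The series", "measured", "known", "first", "only" and "open" are said of these compounds alone.

Compound 1 `Cc1c(OCCCCOc2cccc(C(=O)O)c2)ccc(C(=O)CC2CCCC2)c1O` gives 3400 nM in an assay on HEK293 cells for positive allosteric modulation of metabotropic glutamate receptor 3 (Rattus norvegicus), read by thallium flux, with a stated time of 2.5 min; a lower number here means that less compound is needed, a higher number that more compound is needed for the effect. Compound 2 `COc1ccc(C(=O)O)cc1OCCCCOc1ccc(C(=O)CC2CCCC2)c(O)c1C` differs from compound 1 by methoxy in place of hydrogen on an aromatic carbon, and in this assay compound 2 gives 1020 nM, a step of a 3.3-fold lower number from compound 1 to compound 2 (0.52 log units; beyond the scatter). Compound 3 `Cc1c(OCCCCOc2cccc(C(=O)O)c2)ccc(C(=O)CC(C)C)c1O` has a different core, differing from compound 1 by isopropyl in place of cyclopentyl on a saturated chain carbon bound to a carbonyl carbon, and in this assay compound 3 gives 1430 nM, which is a 2.4-fold lower number from compound 1 to compound 3 (0.38 log units; beyond the scatter). Compound 4 `COc1ccc(C(=O)O)cc1OCCCCOc1ccc(C(=O)CC(C)C)c(O)c1C` has not been measured. It differs from compound 3 by methoxy in place of hydrogen on an aromatic carbon, the same change that turned compound 1 into compound 2, with the same surroundings in both cases. Because that earlier step was a 3.3-fold lower number from compound 1 to compound 2 (0.52 log units; beyond the scatter), a step of similar size is expected here. Compound 4 is therefore estimated at 450 nM, an expected step of a 3.2-fold lower number from compound 3 to compound 4 (0.50 log units; beyond the scatter), and the estimate likely lies between 200 nM and 1000 nM.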

Compound 4, half-maximal effective concentration: 737 nM
The estimate for compound 4 lay 1.6-fold (0.21 log units) below the measured number; measured number inside the range.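

In this assay, adding methoxy to the core of compound 3 gives a 1.9-fold lower number from compound 3 to compound 4 (0.29 log units; within the scatter), and this step can be set beside the earlier one: the same change on two cores in this assay, a 3.3-fold lower number (0.52 log units; beyond the scatter) from compound 1 to compound 2 and a 1.9-fold lower number (0.29 log units; within the scatter) from compound 3 to compound 4, 1.7-fold (0.24 log units) apart, within the scatter of two such steps. Replacing cyclopentyl with isopropyl when methoxy is present gives a 1.4-fold lower number from compound 2 to compound 4 (0.14 log units; within the scatter), which can likewise be compared with its earlier counterpart: the same change on two cores in this assay, a 2.4-fold lower number (0.38 log units; beyond the scatter) from compound 1 to compound 3 and a 1.4-fold lower number (0.14 log units; within the scatter) from compound 2 to compound 4, 1.7-fold (0.24 log units) apart, within the scatter of two such steps. Each change therefore carries across these two cores without a measurable difference in step size, but each new step is within the scatter on its own, and one pair of steps per change sets no rule for the wider series.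

Going by these compounds, it remains open whether ethoxy would behave like methoxy on the aromatic ring. The same question stands for a cyclohexyl or tert-butyl group in place of isopropyl.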